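This account rests on a few compounds, and the source may have more. Where it says the series, first, only, none or still open, it means among the compounds named here.

Three compounds that share one core have been compared in a functional assay on CHO cells with adenosine receptor A1 (Homo sapiens) as the target, read by cAMP accumulation and immunoassay, with a stated time of 6 min, tested at 0.1 uM; a higher number here means a weaker effect of the compound at the concentration tested, a lower number a stronger effect. Compound 1 `Nc1scc(CN2CCN(c3ccc(F)cc3Cl)CC2)c1C(=O)c1ccc(Cl)cc1` gives -6.2%. Compound 2 `Nc1scc(CN2CCN(c3ccc(F)cc3F)CC2)c1C(=O)c1ccc(Cl)cc1` gives -17%, a change described by a number 10.8 percentage points lower from compound 1 to compound 2 (beyond the scatter). Compound 3 `Nc1scc(CN2CCN(c3ccc(F)c(F)c3)CC2)c1C(=O)c1ccc(Cl)cc1` gives -34%, the lowest of the three numbers and therefore the strongest effect seen so far at the tested concentration; its distance from the others is told by a number 17 percentage points lower from compound 2 to compound 3 (beyond the scatter) and a number 27.8 percentage points lower from compound 1 to compound 3 (beyond the scatter), both beyond the scatter and both modest.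

Compound 4 `Nc1scc(CN2CCN(c3c(F)cccc3F)CC2)c1C(=O)c1ccc(Cl)cc1` has not yet been measured. 2,6-difluorophenyl in place of 3,4-difluorophenyl on an amine nitrogen in a ring The two steps that arrived at compound 3 both bear on this: each time a differently substituted phenyl on the ring nitrogen was exchanged for the 3,4-difluorophenyl, the number fell by a modest amount. Among the compounds with values here, compound 4 moves in the opposite sense, away from the 3,4-difluorophenyl, so a rise toward the numbers of compound 1 and compound 2 is the natural expectation, though no measured compound carries the 2,6-difluorophenyl and the size is uncertain. The step is estimated as a number 22 percentage points higher from compound 3 to compound 4 (beyond the scatter). Compound 4 is expected to give about -12%, within a range from -35% to 10%.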

Compound 4, a percentage reported as activity, at one concentration (the size of the read-out at that concentration, not a potency): -23%
Compound 4: the middle estimate sits 11 percentage points above what was measured; the range from low to high includes it.
By their numbers in this assay, from the lowest: compound 3; then compounds 4 and 2 (each within the scatter of the next); then compound 1.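

Compound 3 and compound 4 hold the same atoms, so the change of a number 11 percentage points higher from compound 3 to compound 4 (beyond the scatter) in this assay shows that the read-out responds to where the two fluorines sit on the phenyl, and not only to which halogens it carries. The other two steps separate the phenyl groups further: a number 6 percentage points lower from compound 2 to compound 4 (within the scatter) means that the 2,6-difluorophenyl and the 2,4-difluorophenyl cannot be told apart here, while a number 16.8 percentage points lower from compound 1 to compound 4 (beyond the scatter) sets the 2,6-difluorophenyl clear of the 2-chloro-4-fluorophenyl, leaving the 3,4-difluorophenyl of compound 3 alone with the lowest number of the four. Nothing available explains why these arrangements of the halogens read differently.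

All four compounds carry two halogens on this phenyl, so the compounds shown leave open how a plain unsubstituted phenyl, a phenyl with a single fluorine, or a phenyl with a methoxy group would read on the same ring nitrogen. Each result also comes from a single concentration, so the order seen here says nothing yet about potency, which would need a full concentration series.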